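Replacing the 4-methoxyphenyl of compound 2

A few compounds are considered here, and "the series" means these few. Any claim that something is new, unique, unknown or untested is made for them only; others in the source may bear on it.

Compound 2 `CNC(=O)c1cc(Oc2ccc(C(=O)/C=C/c3ccc(OC)cc3)cc2)ccn1` stands at > 50000 nM in a functional assay on PC-3 cells (Homo sapiens) for cytotoxicity, read by MTT assay, with a stated time of 72 h (a lower number here means a stronger inhibitor, a higher number a weaker inhibitor), which is a limit of the assay and not a number. Compound 1 `CNC(=O)c1cc(Oc2ccc(C(=O)/C=C/c3ccc([N+](=O)[O-])cc3)cc2)ccn1` gives 11100 nM in this assay. Compound 3 `CNC(=O)c1cc(Oc2ccc(C(=O)/C=C/c3cccc(Cl)c3Cl)cc2)ccn1` differs from compound 2 by 2,3-dichlorophenyl in place of 4-methoxyphenyl on a double-bonded chain carbon bound to a double-bonded chain carbon, with 2,3-dichlorophenyl in place of 4-methoxyphenyl. Among the compounds with values here, the only measured step, an at least 4.5-fold higher number from compound 1 to compound 2 (0.65 log units; beyond the scatter), lies beyond the scatter and introduced the methoxy, so a step of similar size towards a lower number is expected on losing that group. The expected change is an at least 3.3-fold lower number from compound 2 to compound 3 (0.52 log units; beyond the scatter). Compound 3 is estimated at 15000 nM, with an expected range of 5000 nM to 50000 nM.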

Compound 3, half-maximal inhibitory concentration: > 50000 nM
Compound 3 gave a limit, no number (the forecaster's own chance of this, stated with the estimate: 20%); at least 3.3-fold (0.52 log units) between middle value and limit.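

In this assay, removing the methoxy does not by itself give a readable value: compound 3, with 2,3-dichlorophenyl in place of 4-methoxyphenyl, also stands at a limit, and the step from compound 2 cannot be read. Of the three aromatic groups at this place, only 4-nitrophenyl gives a number, and 2,3-dichlorophenyl in its place gives an at least 4.5-fold higher number from compound 1 to compound 3 (0.65 log units; beyond the scatter). The series now stops at the assay ceiling for most of its members: the limit of > 50000 nM in this assay, at which 2 of the 3 values shown sit.

As far as these compounds go, it remains open whether the nitro group itself matters or whether another substituent would also give a number. An aminophenyl or carboxyphenyl group at this place would help to separate these possibilities.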